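Phenylsulfanyl for benzylamino at the core of compound 3

A few compounds are considered here, and "the series" means these few. Any claim that something is new, unique, unknown or untested is made for them only; others in the source may bear on it.

Among the measured compounds shown here, compound 1 `Nc1cc(N)c2nc(-c3ccccc3)c(NCc3ccc(Cl)c(Cl)c3)nc2c1` is the only member of the series with a number in a functional assay on K562 cells (Homo sapiens) for inhibition, read by sulforhodamine B assay, with a stated time of 48 h (on this read-out lower numbers stand for stronger inhibition of growth and higher numbers for weaker inhibition of growth), where compound 1 gives 17800 nM. Compound 2 `COc1ccc(CNc2nc3cc(N)cc(N)c3nc2-c2ccccc2)cc1OC` gives < 100000 nM in this assay, which is a limit and not a number. Compound 3 `Nc1cc(N)c2nc(-c3ccccc3)c(NCc3ccc(F)cc3)nc2c1` likewise gives < 100000 nM in this assay, again a limit. The steps a step that the limit leaves unreadable from compound 1 to compound 3 and a step that the two limits leave unreadable from compound 2 to compound 3 therefore cannot be sized, and a step that the limit leaves unreadable from compound 1 to compound 2 is equally unreadable; two of the three values sit at the limit of < 100000 nM in this assay, at which 2 of the 3 values shown sit.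

Compound 4 `Nc1cc(N)c2nc(-c3ccccc3)c(Sc3ccc(F)cc3)nc2c1` differs from compound 3 in one place: (4-fluorophenyl)sulfanyl in place of (4-fluorobenzyl)amino on an aromatic carbon. No measured step in the series concerns this kind of exchange, and the only steps leading to compound 3 are hidden by limits, so no direction beyond the scatter can be expected from the data shown. For the measured compounds named here, the single number of the series in this assay is that of compound 1, which gives 17800 nM. Compound 2 and compound 3 have only limits in this assay. Resting on these, the estimate for compound 4 in this assay is placed at 30000 nM, within 6000 nM to 100000 nM, meaning an expected step that the limit leaves unreadable from compound 3 to compound 4.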

Compound 4, concentration for total growth inhibition: 38900 nM
For compound 4 the middle estimate is 1.3-fold (0.11 log units) below the measured one; measured number inside the range.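

No new step can be read: compound 3 holds only a limit, so the exchange leading to compound 4 cannot be sized: the limit of < 100000 nM in this assay, at which 2 of the 4 values shown sit.

The compounds shown leave open whether (4-fluorophenyl)sulfanyl in place of (4-fluorobenzyl)amino changes growth inhibition at all.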